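Dichlorophenyl in Place of Ethylphenyl on a Urea Nitrogen

A few compounds are considered here, and "the series" means these few. Any claim that something is new, unique, unknown or untested is made for them only; others in the source may bear on it.

Two ureas built on a long unsaturated chain have been measured in an assay on microsomes from intestinal mucosa for inhibition of acyl-CoA:cholesterol acyltransferase (Oryctolagus cuniculus); on this read-out higher numbers stand for weaker inhibition and lower numbers for stronger inhibition. Compound 1 `CCCCCCCC/C=C\CCCCCCCCNC(=O)Nc1c(Cl)cc(Cl)cc1Cl` gives 1200 nM. Compound 2 `CCCCCCCC/C=C\CCCCCCCCNC(=O)Nc1ccccc1CC` gives 980 nM. Within the data shown here, the one change between them, a 1.2-fold lower number from compound 1 to compound 2 (0.09 log units; within the scatter), shows that the two aryl groups cannot be told apart by this assay; compound 2 and compound 1 stand within the scatter of each other, so neither can be called the stronger inhibitor.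

Compound 3 `CCCCCCCC/C=C\CCCCCCCCNC(=O)Nc1c(Cl)cccc1Cl` has not yet been measured. It differs from compound 2 by 2,6-dichlorophenyl in place of 2-ethylphenyl on an amide-type nitrogen. Among the measured compounds shown here, the only step that bears on this change is the one from the trichlorophenyl to the ethylphenyl urea, and it was within the scatter. The dichlorophenyl group of compound 3 keeps two of the three chlorines of compound 1 and drops the ethyl of compound 2, so in this assay the expectation for compound 3 is a step of about a 1.1-fold higher number from compound 2 to compound 3 (0.05 log units; within the scatter), that is, none beyond the scatter. For compound 3 the expected value is therefore 1100 nM, with a range from 500 nM to 2500 nM.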

Compound 3, half-maximal inhibitory concentration: 400 nM
The estimate for compound 3 lay 2.8-fold (0.44 log units) above the measured number; the whole stated range lies above it.
By their numbers in this assay, from the lowest: compound 3; then compounds 2 and 1 (each within the scatter of the next).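

The aryl group on this urea nitrogen does move the number in this assay: 2,6-dichlorophenyl in place of 2-ethylphenyl gives a 2.5-fold lower number from compound 2 to compound 3 (0.39 log units; beyond the scatter) and so shows an effect that the first two compounds did not reveal. Hydrogen in place of chloro on an aromatic carbon also counts, giving a 3.0-fold lower number from compound 1 to compound 3 (0.48 log units; beyond the scatter) here, yet the number does not simply follow how much chlorine the ring carries, since compound 1 and compound 2 stand within the scatter of each other. Nothing available here explains why these changes act as they do.

From the compounds shown here alone, whether the lower number belongs to chlorine itself stays open, and a 2,6-dimethylphenyl or 2,6-difluorophenyl group on the same nitrogen would test that. Going by these compounds, the long unsaturated chain is the same throughout, so the effect of a shorter or saturated chain also remains open.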